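Primary amine in place of benzyl(methyl)amine on the hexyl linker

The compounds below may be only part of what the source reports. "The series", "measured", "known", "first", "only" and "open" are said of these compounds alone.

Compound 2 `CN(CCCCCCOc1ccc2oc(-c3ccccc3)cc(=O)c2c1)Cc1ccccc1` carries the lower of the two numbers recorded so far in an assay on isolated protein (Cavia porcellus) with Sigma non-opioid intracellular receptor 1 (Homo sapiens) as the target, read by radioligand binding (a higher number here means a weaker inhibitor, a lower number a stronger inhibitor), giving 75 nM, while compound 1 `CN(C)CCCCCCCCCCOc1ccc2oc(-c3ccccc3)cc(=O)c2c1` gives 341 nM. For the measured compounds named here, the one measured step, a 4.5-fold lower number from compound 1 to compound 2 (0.66 log units; beyond the scatter), links the two.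

Compound 3 `NCCCCCCOc1ccc2oc(-c3ccccc3)cc(=O)c2c1` differs from compound 2 by amino in place of benzyl(methyl)amino on a saturated chain carbon, six bonds along the chain from an oxygen on an aromatic ring. Going by the values given here, no measured pair covers exactly this change. The step from compound 1 to compound 2 bears on it only indirectly: it shows that the nature of the amine, together with chain length, moved this assay by a modest amount when benzyl(methyl)amino entered. Compound 3 removes that benzyl(methyl)amino altogether and leaves a bare amino. Taking the direction of a 4.5-fold lower number from compound 1 to compound 2 (0.66 log units; beyond the scatter) as a guide, a step of similar or somewhat larger size in the opposite direction is expected, so that compound 3 is estimated at 400 nM, within 120 nM to 1500 nM, which means an expected step of a 5.3-fold higher number from compound 2 to compound 3 (0.73 log units; beyond the scatter).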

Compound 3, half-maximal inhibitory concentration: 3700 nM
Estimate against measurement, compound 3: 9.3-fold (0.97 log units) below; the measured number lies above the stated range.
By their numbers in this assay, from the lowest: compound 2; then compound 1; then compound 3.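

In this assay the group at the end of this chain matters far more than the first pair indicated: a 49-fold higher number from compound 2 to compound 3 (1.69 log units; beyond the scatter) is the change on going to amino, a large step that shows benzyl(methyl)amino cannot be stripped back to amino at this place without a large loss in binding. Amino also falls well behind the 4-(dimethylamino)butyl group, with an 11-fold higher number from compound 1 to compound 3 (1.04 log units; beyond the scatter) as the second large step, so both substituted amines shown give lower numbers than the bare amino, and no compound in this set goes against that order. No measurement at hand accounts for these steps.

Which part of benzyl(methyl)amino carries the large step stays open: a methylamino or a benzylamino group on the same chain would separate the contribution of the methyl from that of the benzyl. A dimethylamino group on the same chain would also separate the nature of the amine from the chain length, two features that remain joined in the comparison of compound 1 with compound 2.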